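From phenyl to 1,3-thiazol-2-yl: what to expect

The compounds below may be only part of what the source reports. "The series", "measured", "known", "first", "only" and "open" are said of these compounds alone.

In a functional assay on A-375 cells (Homo sapiens) for activation, with a stated time of 3 days (on this read-out higher numbers stand for an effect only at larger amounts of compound and lower numbers for an effect already at smaller amounts), compound 3 (`O=C(Nc1ccc(-c2ccccc2)cc1)C1CCCN(Cc2ccc(F)c(F)c2)C1`) gives 5000 nM. Compound 1 (`O=C(Nc1ccc(-c2cscn2)cc1)C1CCCN(Cc2cccc(F)c2)C1`) stands level with it, at 5000 nM. Compound 2 (`O=C(Nc1ccc(-c2cscn2)cc1)C1CCCN(Cc2cccnc2)C1`) gives > 20000 nM, which is a limit of the assay and not a number.

The next molecule, compound 4 (`O=C(Nc1ccc(-c2nccs2)cc1)C1CCCN(Cc2ccc(F)c(F)c2)C1`), differs from compound 3 in one place: 1,3-thiazol-2-yl in place of phenyl on an aromatic carbon. In words, 1,3-thiazol-2-yl stands in place of phenyl on an aromatic carbon.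

For the measured compounds named here, only one measured step changes a single place, and it is not this place. There, pyridin-3-yl takes the place of 3-fluorophenyl on a saturated chain carbon bound to an amine nitrogen in a ring, and the number rises an at least 4.0-fold higher number from compound 1 to compound 2 (0.60 log units; beyond the scatter). Going by these compounds, the true size of that step is unknown, as compound 2 sits at the limit of > 20000 nM in this assay, at which 1 of the 3 values shown sits. It bears on the new change only as a caution that swapping one aromatic ring for another can raise the number beyond the scatter in this assay.

Going by the values given here, with no measured step at the phenyl position, no shift beyond the scatter is expected, though the range stretches further upward. The expected step is a 1.2-fold higher number from compound 3 to compound 4 (0.08 log units; within the scatter). For compound 4, the estimated value is 6000 nM, with an expected range of 2000 nM to 15000 nM.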

Compound 4, half-maximal effective concentration: 800 nM
Estimate against measurement, compound 4: 7.5-fold (0.88 log units) above; measured number outside the range, below it.
By their numbers in this assay, from the lowest: compound 4; then compounds 1 and 3 (each within the scatter of the next). At a limit, above all of these: compound 2.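

The aromatic position para to a large group turns out to matter in this assay: with the rest of the molecule held fixed, 1,3-thiazol-2-yl in place of phenyl gives a 6.3-fold lower number from compound 3 to compound 4 (0.80 log units; beyond the scatter). For the compounds shown here, this is the first measured change at this position, and it shows that replacing one aromatic ring with another can lower the number beyond the scatter, whereas the only earlier step, made elsewhere in the molecule, raised it. The swap changes several things at once, since a six-membered ring of carbon only with 0 hydrogen-bond acceptors gives way to a five-membered ring with nitrogen, sulfur and 2 hydrogen-bond acceptors, and nothing measured here tells which of these differences accounts for the lower number.

This single pair leaves open whether the same swap would lower the number with a different group on the ring amine nitrogen, as only compounds 3 and 4 make the comparison. It also leaves open how this position would respond to a 1,3-oxazol-2-yl ring, which has oxygen in place of sulfur, or to a simple amine.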